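Swapping bromo for methyl on a weak inhibitor

The source may hold more compounds than are shown below. What is called first, only, known or untested is meant among the compounds shown, and "the series" means these compounds.

Of the compounds shown here, three sharing one core have been tested in a functional assay on NCI-H460 cells (Homo sapiens) for inhibition, read by MTT assay, with a stated time of 72 h; on this read-out higher numbers stand for weaker inhibition and lower numbers for stronger inhibition. Compound 1 `CN(C)CCn1c(=O)c(=Cc2ccc(F)c(F)c2)s/c1=C1\C(=O)Nc2cc(F)ccc21` gives 6400 nM in this assay. Compound 3 `CN(C)CCn1c(=O)c(=Cc2ccc(F)c(F)c2)s/c1=C1\C(=O)Nc2ccc(F)cc21` gives 44700 nM. Within the data shown here, compound 2 `CCN(CC)CCCn1c(=O)c(=Cc2ccccc2O)s/c1=C1\C(=O)Nc2ccc(Br)cc21` gives 51700 nM, a number that sits within the scatter of the one from compound 3 and beyond the scatter of the one from compound 1, which lies lower and so marks stronger inhibition.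

Compound 4 `CCN(CC)CCCn1c(=O)c(=Cc2ccccc2O)s/c1=C1\C(=O)Nc2ccc(C)cc21` is compound 2 with one change: methyl in place of bromo on an aromatic carbon. Among the measured compounds shown here, no measured pair in this set shows what such a swap does, so the expectation rests on compound 2 alone. Because compound 2 gives 51700 nM, compound 4 is expected to stay in the same weak region, with a step of a 1.3-fold lower number from compound 2 to compound 4 (0.11 log units; within the scatter) that could fall either way and may well lie within the scatter. The estimate for compound 4 in this assay is 40000 nM, with a range from 12000 nM to 130000 nM.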

Compound 4, half-maximal inhibitory concentration: 11300 nM
Compound 4: the middle estimate sits 3.5-fold (0.55 log units) above what was measured; the whole stated range lies above it.
By their numbers in this assay, from the lowest: compounds 1 and 4 (each within the scatter of the next); then compounds 3 and 2 (each within the scatter of the next).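

In this assay, methyl in place of bromo gives a 4.6-fold lower number from compound 2 to compound 4 (0.66 log units; beyond the scatter), and the lower number marks stronger inhibition. Among these compounds, this is the first single change measured in this set, and it shows that the group on this aromatic carbon of the fused system can shift the read-out beyond the usual scatter, even though bromo and methyl match in every count of heavy atoms, rings, hydrogen-bond donors, hydrogen-bond acceptors and charge. Nothing available explains why this swap strengthens inhibition.

The compounds shown leave open what chloro, methoxy or a plain hydrogen would do on this carbon, and so whether methyl is better than most groups here or bromo is simply poor. Also open, from the compounds shown here alone, is whether methyl in place of the fluoro of compound 3 would bring a similar step.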